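Notes on the step from compound 1 to compound 4

The compounds below may be only part of what the source reports. "The series", "measured", "known", "first", "only" and "open" are said of these compounds alone.

Measured in an ADME assay (Rattus norvegicus, strain Han-wistar) for pharmacokinetics, at a dose of 1.5 umol/kg by the intravenous route; on this read-out higher numbers stand for wider distribution into tissues and lower numbers for narrower distribution:
- compound 1 `CC(C)n1cc(-c2ccnc3[nH]c(C4CCN(CC(=O)N5CCCC5)CC4)cc23)ccc1=O`: 3.9 L/kg
- compound 2 `COc1cc(F)ccc1-c1ccnc2[nH]c(C3CCN(CC(=O)N(C)C)CC3)cc12`: 2.3 L/kg
- compound 3 `CC(C)n1nc(-c2ccnc3[nH]c(C4CCN(CC(=O)N(C)C)CC4)cc23)ccc1=O`: 2.9 L/kg

Among the measured compounds shown here, compound 1 lies within the usual scatter of both compound 2 and compound 3, so these three numbers set no order among the compounds.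

The next compound to be read in this assay is compound 4 `CC(C)n1cc(-c2ccnc3[nH]c(C4CCN(CC(=O)N5CCCCC5)CC4)cc23)ccc1=O`. The change from compound 1 is piperidin-1-yl in place of pyrrolidin-1-yl on a carbonyl carbon.

For the measured compounds named here, no measured step changes the group on the carbonyl carbon alone, so there is no direct precedent. Going by the values given here, the only measured step is a 1.3-fold higher number from compound 2 to compound 3 (0.10 log units; within the scatter). That change sits on an aromatic carbon, so it bears on the present change only indirectly, as a sign that a much larger exchange stayed within the scatter. Compound 1 and compound 3 differ on the carbonyl carbon and elsewhere, and their values also stay within the scatter of each other.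

No step beyond the scatter is therefore expected, and no direction can be supported. The expected step is a 1.1-fold higher number from compound 1 to compound 4 (0.03 log units; within the scatter). Anchored on compound 1 at 3.9 L/kg, the estimate for compound 4 is 4.2 L/kg, with an expected range of 2.4 L/kg to 7 L/kg.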

Compound 4, volume of distribution: 8.1 L/kg
The estimate for compound 4 lay 1.9-fold (0.29 log units) below the measured number; the measured number lies above the stated range.
By their numbers in this assay, from the lowest: compounds 2, 3 and 1 (each within the scatter of the next); then compound 4.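

In this assay, among the compounds shown here, the group on the carbonyl carbon gives the first one-place step that lies beyond the scatter: with piperidin-1-yl in place of pyrrolidin-1-yl, the six-membered non-aromatic ring replacing the five-membered one, the data show a 2.1-fold higher number from compound 1 to compound 4 (0.32 log units; beyond the scatter) as a modest rise. For the compounds shown here, the only earlier one-place step, a 1.3-fold higher number from compound 2 to compound 3 (0.10 log units; within the scatter), exchanged much larger groups on an aromatic carbon and stayed within the scatter, so this read-out can respond to a smaller exchange at the carbonyl carbon than that step suggested, although this finding rests on a single pair. Nothing at hand accounts for the step.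

The compounds shown leave open whether the number keeps rising with ring size, as azepan-1-yl on the same carbonyl carbon would test, or whether it depends on the ring's make-up, as morpholin-4-yl would test. They also leave open whether the same exchange gives a comparable step on the other side of the core, for instance with the fluoro-methoxyphenyl group of compound 2 in place of the pyridone-type group.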